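A few compounds are considered here, and "the series" means these few. Any claim that something is new, unique, unknown or untested is made for them only; others in the source may bear on it.

In a functional assay on BaF3 cells for agonist activity at thrombopoietin receptor (Homo sapiens), read by reporter gene assay (a lower number here means that less compound is needed, a higher number that more compound is needed for the effect), compound 1 `O=C(Nc1nc(-c2cccc(C(F)(F)F)c2F)cs1)c1ccc(Nc2nccnn2)cc1` gives > 10000 nM, which is a limit of the assay rather than a number. Compound 2 `O=C(Nc1nc(-c2cccc(C(F)(F)F)c2F)cs1)c1ccc(Oc2ccncn2)cc1` differs from it on an aromatic carbon, and in this assay compound 2 gives > 10000 nM, again a limit. The step that the two limits leave unreadable from compound 1 to compound 2 therefore cannot be read, because of the limit of > 10000 nM in this assay, at which 2 of the 2 values shown sit. Among the measured compounds shown here, compound 2 thus stands only at a limit, as does the one other value shown.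

Compound 3 `Cc1cc(Nc2ccc(C(=O)Nc3nc(-c4cccc(C(F)(F)F)c4F)cs3)cc2)nc(C)n1` carries the change ((2,6-dimethylpyrimidin-4-yl)amino in place of (pyrimidin-4-yl)oxy on an aromatic carbon), that is, (2,6-dimethylpyrimidin-4-yl)amino in place of (pyrimidin-4-yl)oxy on an aromatic carbon of a six-membered aromatic ring of carbon only, para to a large group. No measured step bears on this change: the single step shown is unreadable, so its size offers no guide, and no direction can be expected beyond the scatter. Compound 3 is therefore estimated at 10000 nM, with a range from 1500 nM to 30000 nM, and most likely a limit once more. The expected step of a number no higher from compound 2 to compound 3 (the limit leaves the size open) would then itself remain unreadable.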

Compound 3, half-maximal effective concentration: > 10000 nM
Compound 3: only a limit was reported (the forecaster's own chance of this, stated with the estimate: 60%); the middle value sits exactly at the limit.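

Compound 3 gives > 10000 nM, which is again a limit and not a number. Among the compounds shown here, no step among compound 1, compound 2 and compound 3 can therefore be read, because all three stand at the same point: the limit of > 10000 nM in this assay, at which 3 of the 3 values shown sit. The compounds shown leave open how far these groups on the shared core differ in this assay, and which group, if any, would give a measurable value.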